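This account rests on a few compounds, and the source may have more. Where it says the series, first, only, none or still open, it means among the compounds named here.

Three compounds have so far been run in a functional assay on HT-29 cells (Homo sapiens) for cytotoxicity, read by MTT assay, with a stated time of 72 h; a lower number here means a stronger inhibitor of growth, a higher number a weaker inhibitor of growth. Compound 3 `[SeH]c1nc([SeH])c2ccccc2n1` gives 45200 nM. Compound 1 `C[Se]c1nc(N)c2ccccc2n1` gives 74800 nM, a number that lies within the usual scatter of the value for compound 3, so the two cannot be told apart on what has been measured. Compound 2 `CSc1nc(NCCCCCO)c2cccnc2n1` reaches only the limit of this assay, reported as > 100000 nM, and therefore supplies no number; this is the limit of > 100000 nM in this assay, at which 1 of the 3 values shown sits. Among the measured compounds shown here, no step between measured compounds that differ in a single place is available from these three.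

Compound 4 `Nc1nc([SeH])nc2ccccc12` has not yet been measured in this assay. It differs from compound 3 in one place: one nitrogen atom in place of one selenium atom, on an aromatic carbon, in words one nitrogen atom in place of one selenium atom, on an aromatic carbon. Compound 1, which also carries an amino group, gives 74800 nM, and that sits close to the value of compound 3 at 45200 nM. On that basis the step that this estimate implies, a 1.5-fold higher number from compound 3 to compound 4 (0.19 log units; within the scatter), is expected to be small, either none beyond the scatter or a slight move toward a higher number. For compound 4 the expected value in this assay is 70000 nM, with a range from 30000 nM to 150000 nM.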

Compound 4, concentration for total growth inhibition: > 100000 nM
Compound 4 was reported as a limit; the forecaster's own chance of this, stated with the estimate: 25%; at least 1.4-fold (0.15 log units) between middle value and limit.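

Among the compounds shown here, putting one nitrogen atom in place of one selenium atom on this aromatic carbon, so that amino enters, gives the first single-place comparison in this assay, and it weakens growth inhibition: the change brings an at least 2.2-fold higher number from compound 3 to compound 4 (0.34 log units; beyond the scatter). With the amino group kept and hydrogen in place of methyl on a selenium, the change brings an at least 1.3-fold higher number from compound 1 to compound 4 (0.12 log units; that floor lies within the scatter), so this second step cannot be told from no change at all. Compound 4 gives only a limit and not a number, which means that both steps are floors and their full size is not known: the limit of > 100000 nM in this assay, at which 2 of the 4 values shown sit.

The compounds shown leave open how much of the loss belongs to the amino group entering and how much to the selenium atom leaving this carbon. They also do not tell whether a hydroxyl group, a methoxy group, a chlorine atom or a longer alkyl chain on this same carbon would keep the growth inhibition seen with compound 3 or lose it as amino does.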